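A few compounds are considered here, and "the series" means these few. Any claim that something is new, unique, unknown or untested is made for them only; others in the source may bear on it.

Measured so far:
compound 1 `COc1ccc(F)cc1CNCCCNc1ccnc2cc(Cc3ccc(F)cc3Cl)ccc12`, 4200 nM
compound 2 `COc1ccc(F)cc1CNCCCNc1ccnc2cc(Cc3ccc(F)cc3)ccc12`, 4200 nM
compound 3 `COc1ccc(F)cc1CNCCCNc1ccnc2cc(Oc3ccccc3)ccc12`, 14500 nM

In a physicochemical assay for solubility, with a stated time of 18 h, at pH 7.4 (a higher number here means a more soluble compound, a lower number a less soluble compound), compound 1 and compound 2 give the same reading, and compound 3 gives the highest of the three. Compound 1 differs from compound 2 by chloro in place of hydrogen on an aromatic carbon, and that change made no change at the digits printed from compound 2 to compound 1 (within the scatter). Compound 3 differs from compound 2 by phenoxy in place of 4-fluorobenzyl on an aromatic carbon, with a 3.5-fold higher number from compound 2 to compound 3 (0.54 log units; beyond the scatter) and, from compound 1, a 3.5-fold higher number from compound 1 to compound 3 (0.54 log units; beyond the scatter).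

Compound 4 `COc1ccc(F)cc1CNCCCNc1ccnc2cc(Oc3ccc(Cl)cc3)ccc12` is not yet measured. It differs from compound 3 by chloro in place of hydrogen on an aromatic carbon. This is the same kind of change as that from compound 2 to compound 1, but the place differs: there the chloro sat ortho to a large group and meta to a fluoro group; here it sits para to a large group, on the phenoxy ring of the core of compound 3 rather than the benzyl ring of the core of compound 2. Because the earlier chloro gave no change at the digits printed from compound 2 to compound 1 (within the scatter), compound 4 is expected to stay near compound 3, with at most a modest downward step, a 1.5-fold lower number from compound 3 to compound 4 (0.16 log units; within the scatter). Compound 4 is estimated at 10000 nM, between 4000 nM and 25000 nM.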

Compound 4, solubility: 14500 nM
Estimate against measurement, compound 4: 1.5-fold (0.16 log units) below; measured number inside the range.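

In this assay chloro in place of hydrogen gave no change at the digits printed from compound 3 to compound 4 (within the scatter) and likewise no change at the digits printed from compound 2 to compound 1 (within the scatter), so across these two cores the change left the reading where it stood. The gap between the two cores also held, with a 3.5-fold higher number from compound 2 to compound 4 (0.54 log units; beyond the scatter) and a 3.5-fold higher number from compound 1 to compound 4 (0.54 log units; beyond the scatter), matching the gap seen with compound 3. For the compounds shown here, this rests on only two pairs, with the chloro at different places, so it does not show that chloro would be silent at one same place on both cores or on any other core, and nothing given here bears on why the readings held.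

Still open, from the compounds shown here alone, is whether a carboxylic acid or an amine on the phenoxy ring would shift the number as chloro did not. Also open, going by these compounds, is what a longer chain in the linker of the shared core would do.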